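Swapping a chlorophenyl amide for a chloropyridinyl amide

A few compounds are considered here, and "the series" means these few. Any claim that something is new, unique, unknown or untested is made for them only; others in the source may bear on it.

Compound 1 `CCCNC(=O)c1ccc(Oc2nc(-c3c(C)noc3C)cnc2N)cc1` gives 6880 nM in a functional assay on HepG2 cells (Homo sapiens) for inhibition, read by MTT assay, with a stated time of 72 h; a lower number here means a stronger inhibitor, a higher number a weaker inhibitor.
Compound 2 `Cc1noc(C)c1-c1cnc(N)c(Oc2ccc(C(=O)NC3CC3)cc2)n1` gives 43200 nM in this assay.
Compound 3 `Cc1noc(C)c1-c1cnc(N)c(Oc2ccc(C(=O)Nc3ccc(Cl)cc3)cc2)n1` gives 14400 nM in this assay.

Compound 3 sits second highest of the three numbers: compound 1 lies below it, as a 2.1-fold higher number from compound 1 to compound 3 (0.32 log units; beyond the scatter) shows, and compound 2 lies above it, as a 3.0-fold lower number from compound 2 to compound 3 (0.48 log units; beyond the scatter) shows. Compound 4 `Cc1noc(C)c1-c1cnc(N)c(Oc2ccc(C(=O)Nc3cccc(Cl)n3)cc2)n1` has not yet been measured. The change is 6-chloropyridin-2-yl in place of 4-chlorophenyl on an amide-type nitrogen. For the measured compounds named here, none of the measured steps exchanges one aromatic ring for another; they only show that the group on the amide nitrogen shifts the number modestly, as a 6.3-fold higher number from compound 1 to compound 2 (0.80 log units; beyond the scatter) illustrates. The expectation for this assay is therefore a step of a 1.0-fold lower number from compound 3 to compound 4 (0.01 log units; within the scatter), within the usual scatter. Compound 4 is estimated at 14000 nM, with a range from 5000 nM to 40000 nM.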

Compound 4, half-maximal inhibitory concentration: 35700 nM
Beside the measured number, compound 4's estimate is 2.6-fold (0.41 log units) below it; measured number inside the range.
By their numbers in this assay, from the lowest: compound 1; then compound 3; then compounds 4 and 2 (each within the scatter of the next).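

Exchanging one aromatic ring for another on the amide-type nitrogen does move the number in this assay: the step is a 2.5-fold higher number from compound 3 to compound 4 (0.39 log units; beyond the scatter), and it brings in a ring nitrogen while also changing where the chlorine stands. The result cannot be told apart from the cyclopropyl amide (a 1.2-fold lower number from compound 2 to compound 4 (0.08 log units; within the scatter)) and remains weaker than the propyl amide (a 5.2-fold higher number from compound 1 to compound 4 (0.72 log units; beyond the scatter)). No measurement here explains the step.

As far as these compounds go, whether the ring nitrogen or the chlorine's new place matters more stays open. So does how a plain pyridin-2-yl or a longer butyl chain would read.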